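Replacing the phenoxy head of compound 3 with a methyl(phenyl)amino group

The source may report more compounds than this note shows. Statements on the series, on what has been measured and on what is new or still open speak of the compounds shown alone.

Measured compounds:
compound 1 `COc1cc(C(C)=O)ccc1OCCCN1CCC(C(c2cccc(F)c2)c2cccc(F)c2)CC1`: 3.16 nM
compound 2 `COc1cc(C(C)=O)ccc1OCCCN1CCC(C(c2ccc(F)cc2)C2CCCCC2)CC1`: 5.01 nM
compound 3 `COc1cc(C(C)O)ccc1OCCCN1CCC(C(c2ccc(F)cc2)c2ccc(F)cc2)CC1`: 10 nM

Of the compounds shown here, three have been measured in a functional assay (aorta) with Oryctolagus cuniculus as the target; a lower number here means tighter binding, a higher number weaker binding. Compound 1 gives 3.16 nM in this assay, compound 2 gives 5.01 nM, and compound 3 gives 10 nM. Compound 3 therefore has the highest of the three numbers; its gap to compound 2 lies within the scatter of repeated measurements, while its gap to compound 1 lies beyond it. No two of these compounds differ in only one place, so no single step between them can be read off.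

Compound 4 `CN(CCCN1CCC(C(c2ccc(F)cc2)c2ccc(F)cc2)CC1)c1ccccc1` has not yet been measured in this assay. Relative to compound 3 it carries methyl(phenyl)amino in place of 4-(1-hydroxyethyl)-2-methoxyphenoxy on a saturated chain carbon, three bonds along the chain from an amine nitrogen in a ring. Going by the values given here, nothing among the measured compounds speaks directly to this change, as all three share a phenoxy head. On that basis compound 4 is expected to give 30 nM in this assay, within a range of 5 nM to 200 nM. The expected step of a 3.0-fold higher number from compound 3 to compound 4 (0.48 log units; beyond the scatter) is thus a modest rise in the dissociation constant, held with little confidence either way.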

Compound 4, dissociation constant: 2 nM
Beside the measured number, compound 4's estimate is 15-fold (1.18 log units) above it, and the stated range ends above it.
By their numbers in this assay, from the lowest: compounds 4, 1, 2 and 3 (each within the scatter of the next, the first and the last beyond it).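

In this assay, putting methyl(phenyl)amino in place of 4-(1-hydroxyethyl)-2-methoxyphenoxy on a saturated chain carbon, three bonds along the chain from an amine nitrogen in a ring, gives a 5.0-fold lower number from compound 3 to compound 4 (0.70 log units; beyond the scatter). The earlier compounds shown here all carried a phenoxy head, so they could not show that this position accepts a head without one. The incoming group has fewer heavy atoms, no hydrogen-bond donor and fewer hydrogen-bond acceptors, yet the number does not rise. No measurement at hand accounts for the fall.

The whole head changes in this one step, so the share of each part of it remains unresolved. On these data alone, it also remains open whether a benzyl(methyl)amino group or an anilide carbonyl would serve in the same place.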